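A New Aryl Group on the Sulfonyl Sulfur

A few compounds are considered here, and "the series" means these few. Any claim that something is new, unique, unknown or untested is made for them only; others in the source may bear on it.

In a functional assay on CWR22R cells (Homo sapiens) for antiproliferative activity, read by propidium iodide staining, with a stated time of 96 h (a higher number here means a weaker inhibitor, a lower number a stronger inhibitor), compound 1 (`CC(O)(CS(=O)(=O)c1ccc(S(F)(F)(F)(F)F)cc1)C(=O)Nc1ccc(S(F)(F)(F)(F)F)cc1`) gives 17300 nM and compound 2 (`CC(O)(CS(=O)(=O)c1cccc(C(F)(F)F)c1)C(=O)Nc1ccc(S(F)(F)(F)(F)F)cc1`) gives 23800 nM while compound 3 (`CC(O)(CS(=O)(=O)c1ccccc1C(F)(F)F)C(=O)Nc1ccc(S(F)(F)(F)(F)F)cc1`) gives 17400 nM and so sits within the scatter of both. Compound 4 (`CC(O)(CS(=O)(=O)c1ccc(OC(F)(F)F)cc1)C(=O)Nc1ccc(S(F)(F)(F)(F)F)cc1`) has not been measured yet. It differs from compound 3 in one place: 4-(trifluoromethoxy)phenyl in place of 2-(trifluoromethyl)phenyl on a sulfonyl sulfur with 4-(trifluoromethoxy)phenyl in place of 2-(trifluoromethyl)phenyl on a sulfonyl sulfur. The closest measured comparison is 2-(trifluoromethyl)phenyl in place of 3-(trifluoromethyl)phenyl, which gave a 1.4-fold lower number from compound 2 to compound 3 (0.14 log units; within the scatter) and so shows no real difference. Compound 1 at 17300 nM carries yet another group on that sulfur and still falls in the same range. These few results give no sign that this position moves the number, so no step beyond the scatter is expected in this assay here. The estimated step is a 1.1-fold higher number from compound 3 to compound 4 (0.04 log units; within the scatter) and nothing larger is expected. For compound 4 the estimated value is 19000 nM within an expected range from 10000 nM to 32000 nM in this assay.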

Compound 4, half-maximal inhibitory concentration: 51900 nM
Compound 4: middle estimate off by 2.7-fold (0.44 log units), on the low side; measured number above the stated range.
By their numbers in this assay, from the lowest: compounds 1, 3 and 2 (each within the scatter of the next); then compound 4.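

The aryl group on the sulfonyl sulfur does move the number in this assay: 4-(trifluoromethoxy)phenyl in place of 2-(trifluoromethyl)phenyl gives a 3.0-fold higher number from compound 3 to compound 4 (0.47 log units; beyond the scatter) and in place of 3-(trifluoromethyl)phenyl gives a 2.2-fold higher number from compound 2 to compound 4 (0.34 log units; beyond the scatter), whereas the earlier swap between the two trifluoromethyl groups stayed within the scatter. Trifluoromethoxy in place of the pentafluorosulfanyl group on that ring gives a 3.0-fold higher number from compound 1 to compound 4 (0.48 log units; beyond the scatter), so the rise goes with this one group and not with every aryl group shown on this sulfur. No measurement here accounts for the rise.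

Still open, going by these compounds, is whether the rise follows the oxygen of the trifluoromethoxy group or the group's place on the ring, which a 4-(trifluoromethyl)phenyl group on the sulfonyl sulfur could separate. On these data alone, how an amine or a carboxylic acid on this ring would behave also remains unknown.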